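The source may report more compounds than this note shows. Statements on the series, on what has been measured and on what is new or still open speak of the compounds shown alone.

Measured so far in an assay on cells for agonist activity at ecdysone receptor (Bombyx mori), read by a luciferase reporter, with a stated time of 24 h; a lower number here means that less compound is needed, a higher number that more compound is needed for the effect:

Compound 1 `CC(C)(C)N(NC(=O)c1ccccc1F)C(=O)c1ccccc1Cl` gives 51.3 nM.
Compound 2 `CC(C)(C)N(NC(=O)c1ccccc1Cl)C(=O)c1ccccc1Cl` gives 331 nM.
Compound 3 `CC(C)(C)N(NC(=O)c1ccc(Br)cc1)C(=O)c1ccccc1Cl` gives 33.9 nM.

Compound 3 has the lowest number of the three. Its nearest neighbour is compound 1, and the gap between them, a 1.5-fold lower number from compound 1 to compound 3 (0.18 log units; within the scatter), lies within the scatter, so the two cannot be ranked. The gap to compound 2, a 9.8-fold lower number from compound 2 to compound 3 (0.99 log units; beyond the scatter), is beyond the scatter.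

Compound 4 `Cc1ccc(C(=O)NN(C(=O)c2ccccc2Cl)C(C)(C)C)cc1C` differs from compound 3 in one place: 3,4-dimethylphenyl in place of 4-bromophenyl on a carbonyl carbon. Among the compounds with values here, both measured steps that touch this position, a 1.5-fold lower number from compound 1 to compound 3 (0.18 log units; within the scatter) and a 9.8-fold lower number from compound 2 to compound 3 (0.99 log units; beyond the scatter), concern halogen-bearing rings only; no measured step introduces a ring carrying two methyl groups, so the size and direction of the change are not anchored by the data. With a ring of similar size but without a halogen, the number for compound 4 is expected to stay close to that of compound 3, a step of a 1.5-fold higher number from compound 3 to compound 4 (0.17 log units; within the scatter) in this assay being the estimate. Compound 4 is therefore estimated at 50 nM, within a range of 15 nM to 200 nM.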

Compound 4, half-maximal effective concentration: 87.1 nM
Estimate against measurement, compound 4: 1.7-fold (0.24 log units) below; the measured number falls inside the stated range.
By their numbers in this assay, from the lowest: compounds 3, 1 and 4 (each within the scatter of the next, the first and the last beyond it); then compound 2.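

Until now every ring at this position carried a halogen. Compound 4 shows that the 3,4-dimethylphenyl ring, which has none, can still give a lower number than the 2-chlorophenyl ring (a 3.8-fold lower number from compound 2 to compound 4 (0.58 log units; beyond the scatter)) in this assay, so among these compounds a halogen on this ring is not needed for a low number. It does not match the 4-bromophenyl ring (a 2.6-fold higher number from compound 3 to compound 4 (0.41 log units; beyond the scatter)), and it cannot be ranked against the 2-fluorophenyl ring (a 1.7-fold higher number from compound 1 to compound 4 (0.23 log units; within the scatter)); no measured evidence explains these differences.

The compounds shown leave open whether one methyl group on this ring would serve as well as two, and how a ring carrying a methoxy group or an amine would compare. Also open, going by these compounds, is whether these steps would keep their size if the rest of the shared core changed.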